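The source may report more compounds than this note shows. Statements on the series, on what has been measured and on what is new or still open speak of the compounds shown alone.

Within the data shown here, in a functional assay on MT4 cells (Homo sapiens) (on this read-out higher numbers stand for lower toxicity in this test and lower numbers for higher toxicity in this test), compound 1 `Cc1cn([C@@H]2O[C@H](CO[Si](C)(C)C(C)(C)C)[C@@]3(OS(=O)(=O)C=C3NCC(N)=O)[C@H]2O[Si](C)(C)C(C)(C)C)c(=O)n(C)c1=O` gives 14900 nM, the only exact number so far. Compound 2 `Cc1cn([C@@H]2O[C@@H]3COC(=O)[C@]3(OS(C)(=O)=O)[C@H]2O)c(=O)[nH]c1=O` is recorded only as a limit of the test, >= 250000 nM. Compound 3 `C=C(C)C(=O)NC(=O)NC1=CS(=O)(=O)O[C@@]12[C@@H](CO[Si](C)(C)C(C)(C)C)O[C@@H](n1cc(C)c(=O)n(C)c1=O)[C@@H]2O[Si](C)(C)C(C)(C)C` keeps the core of compound 1 but carries ((1-methylethenyl)carbonyl)carbamoyl in place of carbamoylmethyl on an amine nitrogen. Among the measured compounds shown here, no measured pair shows what such a swap does to toxicity, so no shift beyond the usual scatter is assumed. The expected step of a 1.1-fold higher number from compound 1 to compound 3 (0.03 log units; within the scatter) is therefore small. Compound 3 is estimated at 16000 nM, with an expected range of 5000 nM to 50000 nM.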

Compound 3, half-maximal cytotoxic concentration: 1190 nM
The estimate for compound 3 lay 13-fold (1.13 log units) above the measured number; the measured number lies below the stated range.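

In this assay, among these compounds, putting ((1-methylethenyl)carbonyl)carbamoyl in place of carbamoylmethyl on the amine nitrogen gives a 13-fold lower number from compound 1 to compound 3 (1.10 log units; beyond the scatter), the first change on this core that can be read as a step. The group on this nitrogen can therefore move toxicity in this test well beyond the usual scatter. Nothing shown explains why.

One swap cannot show whether the 1-methylethenyl end or the carbamoyl part carries the step. Going by these compounds, what a plain acetyl group or a longer alkyl chain would do on this nitrogen also remains open.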